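Swapping bromo for trifluoromethyl on a coumarin-triazole ether

The source may hold more compounds than are shown below. What is called first, only, known or untested is meant among the compounds shown, and "the series" means these compounds.

Of the compounds shown here, two have been measured in a functional assay on MCF7 cells (Homo sapiens) for antiproliferative activity, read by MTT assay, with a stated time of 48 h; a lower number here means a stronger inhibitor, a higher number a weaker inhibitor. Compound 1 `CCc1ccc(OCc2cn(-c3cc(=O)oc4ccc(Br)cc34)nn2)cc1` gives 12700 nM. Compound 2 `O=c1cc(-n2cc(COc3ccc(Br)cc3)nn2)c2cc(Br)ccc2o1` gives 1920 nM. Within the data shown here, compound 2 therefore holds the lowest of the two numbers, with the only neighbour being compound 1, whose number is higher. Among the measured compounds shown here, the single measured step, a 6.6-fold lower number from compound 1 to compound 2 (0.82 log units; beyond the scatter), concerns the same position that is changed next.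

Compound 3 `O=c1cc(-n2cc(COc3ccc(C(F)(F)F)cc3)nn2)c2cc(Br)ccc2o1` differs from compound 2 in one place: trifluoromethyl in place of bromo on an aromatic carbon. For the measured compounds named here, no measured step covers bromo giving way to trifluoromethyl, so the direction cannot be read off directly. The step from compound 1 to compound 2 does show that this position on the phenyl ether can move the number well beyond the scatter, so a change there cannot be dismissed as neutral. With no closer comparison, the expected step from compound 2 to compound 3 is a 1.4-fold higher number from compound 2 to compound 3 (0.15 log units; within the scatter), kept near the scatter. Compound 3 is therefore estimated at 2700 nM, with a range from 800 nM to 9000 nM.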

Compound 3, half-maximal inhibitory concentration: 11400 nM
Beside the measured number, compound 3's estimate is 4.2-fold (0.63 log units) below it, and the stated range ends below it.
By their numbers in this assay, from the lowest: compound 2; then compounds 3 and 1 (each within the scatter of the next).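

The change from bromo to trifluoromethyl in this assay is far from neutral: the measured result is a 5.9-fold higher number from compound 2 to compound 3 (0.77 log units; beyond the scatter) and so bromo cannot be treated as interchangeable with trifluoromethyl at this place on the phenyl ether. The other new comparison is a 1.1-fold lower number from compound 1 to compound 3 (0.05 log units; within the scatter) and so ethyl and trifluoromethyl cannot be told apart here, which leaves compound 2, with bromo, as the only one of the three set apart from the others, and its steps to both are beyond the scatter. Among these compounds, nothing measured so far accounts for what sets bromo apart from these two groups.

Among the compounds shown here, with only three groups compared at this position, a single result for bromo cannot show whether other halogens, such as chloro or iodo, would give similarly low numbers. On these data alone, it is also open how a methoxy group, an amine or a carboxylic acid at the same place would compare, and whether bromo keeps its advantage when the bromo on the shared core is replaced.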